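Aryl methoxy to fluoro on the core of compound 3

The source may report more compounds than this note shows. Statements on the series, on what has been measured and on what is new or still open speak of the compounds shown alone.

Measured so far in a functional assay on CHO cells for agonist activity at Melanocyte-stimulating hormone receptor (Homo sapiens), read by a luciferase reporter, with a stated time of 4 h; on this read-out higher numbers stand for an effect only at larger amounts of compound and lower numbers for an effect already at smaller amounts:
Compound 1, `CC(C)N(C(=O)CN1C=CN(c2ccccc2)C(=O)C(Cc2n[nH]c3ccccc23)C1=O)c1ccc(F)cc1`: 50.1 nM
Compound 2, `COc1ccc(N(C(=O)CN2C=CN(c3ccccc3)C(=O)C(Cc3cc[nH]n3)(Cc3n[nH]c4ccccc34)C2=O)C(C)C)cc1`: 398 nM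
Compound 3, `COc1ccc(N(C(=O)CN2C=CN(c3ccccc3)C(=O)C(Cc3n[nH]c4ccccc34)(OC)C2=O)C(C)C)cc1`: 1380 nM

Going by the values given here, compound 3 gives the highest number of the three; the nearest is compound 2, and the only single-point step, a 3.5-fold higher number from compound 2 to compound 3 (0.54 log units; beyond the scatter), goes beyond the scatter.

Compound 4, `COC1(Cc2n[nH]c3ccccc23)C(=O)N(CC(=O)N(c2ccc(F)cc2)C(C)C)C=CN(c2ccccc2)C1=O`, differs from compound 3 by fluoro in place of methoxy on an aromatic carbon, read one bond out as 4-methoxyphenyl to 4-fluorophenyl. Among the compounds with values here, no measured step isolates this change: compound 1, which carries the fluorophenyl, differs from compound 3 in a second place as well, so its lower number cannot be credited to the aryl substituent alone. For compound 4 the expected step, with wide uncertainty, is a 1.7-fold lower number from compound 3 to compound 4 (0.24 log units; within the scatter). For compound 4 the estimate is 800 nM, between 250 nM and 2500 nM.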

Compound 4, half-maximal effective concentration: 2950 nM
Estimate against measurement, compound 4: 3.7-fold (0.57 log units) below; measured number above the stated range.
By their numbers in this assay, from the lowest: compound 1; then compound 2; then compound 3; then compound 4.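

Fluoro in place of methoxy on the aromatic carbon, with the methoxy on the saturated ring carbon kept, gives a 2.1-fold higher number from compound 3 to compound 4 (0.33 log units; beyond the scatter) and so does not lower the number in this pair. The saturated ring carbon weighs far more on the fluorophenyl side: methoxy in place of hydrogen gives a 59-fold higher number from compound 1 to compound 4 (1.77 log units; beyond the scatter), a much larger step than the aryl change. No available evidence bears on either step.

As far as these compounds go, whether the aryl step holds with hydrogen on the saturated ring carbon remains open. So does the reading of an amine or a carboxylic acid at that aromatic carbon.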